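The compounds below may be only part of what the source reports. "The series", "measured", "known", "first", "only" and "open" are said of these compounds alone.

Compound 1 `Fc1ccccc1CSc1nnc(-c2cnccn2)o1` gives 25300 nM in a functional assay on HeLa cells (Homo sapiens) for antiproliferative activity, read by MTT assay, with a stated time of 48 h; on this read-out higher numbers stand for weaker inhibition and lower numbers for stronger inhibition.
Compound 2 `Fc1cccc(F)c1CSc1nnc(-c2cnccn2)o1` gives, in this assay, only a limit of the assay and not a number: > 50000 nM.
Compound 3 `Fc1ccccc1CSc1nnc(-c2cnccn2)s1` gives 32700 nM in this assay.

Compound 1 and compound 2 differ by a single change, (fluoro in place of hydrogen on an aromatic carbon). On this assay this change gave an at least 1.9-fold higher number from compound 1 to compound 2 (0.29 log units; that floor lies within the scatter). Because the value of compound 2 sits at the limit of > 50000 nM in this assay, at which 1 of the 3 values shown sits, the true size of that step is known only as a floor. How the core of compound 1 differs from the core of compound 3 is not broken down here; their two values in this assay lie within the scatter of each other. Compound 4 `Fc1cccc(F)c1CSc1nnc(-c2cnccn2)s1` has not yet been measured. From compound 3 to compound 4 the same change is made, (fluoro in place of hydrogen on an aromatic carbon), at a place described in the same words. Resting on the step from compound 1 to compound 2, the expected step from compound 3 to compound 4 in this assay is a 2.3-fold higher number from compound 3 to compound 4 (0.36 log units; beyond the scatter). Compound 4 is therefore estimated at 75000 nM, expected to fall between 40000 nM and 160000 nM, and quite possibly to be reported as a limit of this assay.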

Compound 4, half-maximal inhibitory concentration: 29200 nM
Estimate against measurement, compound 4: 2.6-fold (0.41 log units) above; the whole stated range lies above it.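

In this assay, the same change on the core of compound 3 gives a 1.1-fold lower number from compound 3 to compound 4 (0.05 log units; within the scatter), so on this core the step stays within the scatter. This does not show that the change carries over from one core to the other, nor that it fails to, as the two steps can only be set side by side: the same change on two cores in this assay, an at least 1.9-fold higher number (0.29 log units; that floor lies within the scatter) from compound 1 to compound 2 and a 1.1-fold lower number (0.05 log units; within the scatter) from compound 3 to compound 4; the limit leaves it open whether they differ. Going by these compounds, the size of the first step stays unknown, since what compound 2 gives is a limit and not a number: the limit of > 50000 nM in this assay, at which 1 of the 4 values shown sits.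

The compounds shown carry only fluoro groups on the six-membered aromatic ring of carbon only. On these data alone, whether a chloro group, a methoxy group or an amine at that place would give a different number on either core remains open.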